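Thiophene to furan swap in the sulfonamide series

A few compounds are considered here, and "the series" means these few. Any claim that something is new, unique, unknown or untested is made for them only; others in the source may bear on it.

Among the compounds with values here, compound 1 `Cc1ccc(S(=O)(=O)N(CCC#N)Cc2cccs2)cc1` is the anchor of the set in an ADME assay on MDCK cells (Canis lupus familiaris) for cytotoxicity, read by MTT assay, with a stated time of 24 h; on this read-out lower numbers stand for higher toxicity in this test and higher numbers for lower toxicity in this test: compound 1 gives 127000 nM and is the only member with a number rather than a limit. Compound 2 `N#CCCN(Cc1cccs1)S(=O)(=O)c1ccc(C#N)cc1` reaches only the assay limit in this assay, reported as > 201000 nM. Going by these compounds, the step of an at least 1.5-fold higher number from compound 1 to compound 2 (0.19 log units; that floor lies within the scatter) thus rests on a limit (the limit of > 201000 nM in this assay, at which 1 of the 2 values shown sits), so its true size stays open.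

Compound 3 `Cc1ccc(S(=O)(=O)N(CCC#N)Cc2ccco2)cc1` is not yet measured. It differs from compound 1 in one place: furan-2-yl in place of thiophen-2-yl on a saturated chain carbon bound to a sulfonamide nitrogen. Within the data shown here, no measured step covers this change; the single step known concerns a different part of the molecule, the substituent on the aromatic carbon of the sulfonyl ring. No shift beyond the scatter is expected, and the estimated step of a 1.1-fold higher number from compound 1 to compound 3 (0.04 log units; within the scatter) reflects that. Compound 3 is expected to give 140000 nM in this assay, within a range of 60000 nM to 320000 nM.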

Compound 3, half-maximal cytotoxic concentration: > 219000 nM
Compound 3 ended at the assay's limit (the forecaster's own chance of this, stated with the estimate: 30%); at least 1.5-fold (0.19 log units) between middle value and limit.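

Unlike the cyano step, this change sits on a saturated chain carbon bound to a sulfonamide nitrogen, and in this assay furan-2-yl in place of thiophen-2-yl gives an at least 1.7-fold higher number from compound 1 to compound 3 (0.23 log units; that floor lies within the scatter). Compound 3 reaches a limit of the assay rather than a number: the limit of > 219000 nM in this assay, at which 1 of the 3 values shown sits. Compound 1 therefore remains the only member with a number, and changes at two different places, in compound 2 and compound 3, both end at a limit, so a real rise at this position is neither shown nor excluded.

The compounds shown leave open how far compound 3 lies past its limit, and whether furan-2-yl keeps the same standing when paired with the cyano group of compound 2. Also open, going by these compounds, is what a carboxylic acid or an amine in place of the chain nitrile would do to this read-out.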